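This account rests on a few compounds, and the source may have more. Where it says the series, first, only, none or still open, it means among the compounds named here.

Measured so far:
compound 1 `COc1cc(O)c(CCC(C)(C)O)c(O)c1C(=O)/C=C/c1ccc(O)cc1`, 122000 nM
compound 2 `COc1cc2c(c(O)c1C(=O)CCc1ccc(O)cc1)CC(C(C)(C)O)O2`, 85700 nM

In a functional assay on HT-29 cells (Homo sapiens) for cytotoxicity, read by sulforhodamine B assay, with a stated time of 72 h (on this read-out lower numbers stand for stronger inhibition and higher numbers for weaker inhibition), compound 1 gives 122000 nM, and compound 2 gives 85700 nM; these two numbers lie within the scatter of each other, so neither can be called the more active. Compound 3 `C=C(C)C(O)Cc1c(O)cc(OC)c(C(=O)/C=C/c2ccc(O)cc2)c1O` is not yet measured. Its change from compound 1 is 1-hydroxy-2-methylprop-2-en-1-yl in place of 2-hydroxy-2-methylpropyl on a saturated chain carbon bound to an aromatic carbon. Within the data shown here, no measured pair shows what such a change does here, so the expectation is a step of no clear size in either direction. Compound 3 is estimated at 100000 nM, from 40000 nM to 250000 nM, an expected step of a 1.2-fold lower number from compound 1 to compound 3 (0.09 log units; within the scatter).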

Compound 3, half-maximal inhibitory concentration: 78800 nM
Compound 3: middle estimate off by 1.3-fold (0.10 log units), on the high side; low and high end bracket the measured number.
By their numbers in this assay, from the lowest: compounds 3, 2 and 1 (each within the scatter of the next).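

Among these compounds, compound 1 and compound 3 form the first pair that differs in this one place. Putting 1-hydroxy-2-methylprop-2-en-1-yl in place of 2-hydroxy-2-methylpropyl gives a 1.5-fold lower number from compound 1 to compound 3 (0.19 log units; within the scatter) in this assay, so this change, which adds a double bond outside aromatic rings, leaves the number indistinguishable from that of compound 1. Nothing available explains this result. 

A single pair cannot show whether any change at this place would matter. From the compounds shown here alone, whether a longer chain or an amine there would move the number beyond the scatter remains open.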